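From Compound 1 to Compound 4 in Cytotoxicity

The source may report more compounds than this note shows. Statements on the series, on what has been measured and on what is new or still open speak of the compounds shown alone.

For the measured compounds named here, compound 1 `O=C(CSc1nnc(-c2ccncc2)o1)N/N=C/c1ccccc1` gives 22100 nM in a functional assay on BGC-823 cells (Homo sapiens) for cytotoxicity, read by MTT assay, with a stated time of 48 h (a lower number here means a stronger inhibitor, a higher number a weaker inhibitor), the second highest of the three numbers measured so far. Compound 2 `O=C(CSc1nnc(-c2ccncc2)o1)N/N=C/c1ccccc1[N+](=O)[O-]` carries a nitro in place of hydrogen on an aromatic carbon and gives 41600 nM, a step of a 1.9-fold higher number from compound 1 to compound 2 (0.27 log units; within the scatter). Compound 3 `O=C(CSc1nnc(-c2ccncc2)o1)N/N=C/c1cc(Br)cc(Br)c1O` carries 3,5-dibromo-2-hydroxyphenyl in place of phenyl on a carbon with a double bond to nitrogen and gives 9610 nM, a step of a 2.3-fold lower number from compound 1 to compound 3 (0.36 log units; beyond the scatter); measured against compound 2 the step is a 4.3-fold lower number from compound 2 to compound 3 (0.64 log units; beyond the scatter).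

Compound 4 `O=C(CSc1nnc(-c2ccncc2)o1)N/N=C/C=C/c1ccccc1` arises from compound 1 by 2-phenylethenyl in place of phenyl on a carbon with a double bond to nitrogen. Going by the values given here, no measured step makes this exact change: compounds 2 and 3 keep a ring directly on the carbon with a double bond to nitrogen and vary only what that ring carries, whereas compound 4 places 2-phenylethenyl there. Since those two steps, one within the scatter and one modest, moved this assay only a little, the step of a 1.1-fold lower number from compound 1 to compound 4 (0.04 log units; within the scatter) is expected to stay within or close to the scatter. Compound 4 is therefore estimated at 20000 nM, with a range from 8000 nM to 50000 nM.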

Compound 4, half-maximal inhibitory concentration: 10600 nM
Compound 4: the middle estimate sits 1.9-fold (0.28 log units) above what was measured; the range from low to high includes it.
By their numbers in this assay, from the lowest: compounds 3 and 4 (each within the scatter of the next); then compounds 1 and 2 (each within the scatter of the next).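

In this assay, for the compounds shown here, the change of phenyl to 2-phenylethenyl on a carbon with a double bond to nitrogen gives a step beyond the scatter (a 2.1-fold lower number from compound 1 to compound 4 (0.32 log units; beyond the scatter)), which among the earlier compounds only 3,5-dibromo-2-hydroxyphenyl had given. The group that enters here carries no substituent on its ring and adds only a double bond outside aromatic rings, yet its value cannot be told apart from that of 3,5-dibromo-2-hydroxyphenyl (a 1.1-fold higher number from compound 3 to compound 4 (0.04 log units; within the scatter)). Against 2-nitrophenyl the change gives a larger step (a 3.9-fold lower number from compound 2 to compound 4 (0.59 log units; beyond the scatter)).

As far as these compounds go, whether 2-phenylethyl, or 2-phenylethenyl carrying an amine or a carboxylic acid on its ring, would give a similar number remains open. Nothing measured here accounts for how the number moves at this position.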